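The source may report more compounds than this note shows. Statements on the series, on what has been measured and on what is new or still open speak of the compounds shown alone.

Compound 1 `Fc1ccc(Nc2cc3[nH]c(Nc4ccc(N5CCNCC5)cn4)nc3cn2)cc1C(F)(F)F`: 14000 nM
Compound 2 `Fc1ccc(Nc2cc3[nH]c(Nc4cc(N5CCNCC5)ccn4)nc3cn2)cc1C(F)(F)F`: 31000 nM

Both compounds were tested in an ADME assay on CHO cells (Cricetulus griseus) for cytotoxicity, read by MTT assay; on this read-out lower numbers stand for higher toxicity in this test and higher numbers for lower toxicity in this test. Compound 1 has the lower number, 14000 nM, so it is the more toxic of the two in this assay. Compound 2 gives 31000 nM, and this gap lies beyond the usual scatter of repeated measurements.

Compound 3 `Fc1ccc(Nc2cc3[nH]c(Nc4ccc(N5CCN(C6CC6)CC5)cn4)nc3cn2)cc1C(F)(F)F` has not been measured yet. It differs from compound 1 in one place: cyclopropyl in place of hydrogen on an amine nitrogen in a ring. Put simply, cyclopropyl stands in place of hydrogen on an amine nitrogen in a ring, turning piperazin-1-yl into 4-cyclopropylpiperazin-1-yl.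

Going by the values given here, no measured pair here shows the effect of this change, so any forecast rests on thin evidence. Among the compounds with values here, the only guide is the span of the two known values. The expectation in this assay is therefore no step beyond the scatter, in either direction. The estimated step of a 1.1-fold higher number from compound 1 to compound 3 (0.03 log units; within the scatter) is accordingly small. For compound 3 the expected value is 15000 nM, with an estimated range from 6000 nM to 40000 nM.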

Compound 3, half-maximal cytotoxic concentration: 23000 nM
The estimate for compound 3 lay 1.5-fold (0.19 log units) below the measured number, within the range that was stated.
By their numbers in this assay, from the lowest: compounds 1, 3 and 2 (each within the scatter of the next, the first and the last beyond it).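

Turning piperazin-1-yl into 4-cyclopropylpiperazin-1-yl gives, in this assay, a 1.6-fold higher number from compound 1 to compound 3 (0.22 log units; within the scatter), so on this read-out a cyclopropyl group on this amine nitrogen leaves the number within what repeated measurements of one compound could show. Going by these compounds alone, until now no pair of compounds spoke to this nitrogen at all; this pair shows that one small carbon ring can stand in place of the hydrogen with no step that can be told apart from the scatter, but one pair is a single example and not a trend. Nothing in the available data explains the result, and it offers no measured property that bears on it.

On these data alone, what stays open is whether other groups on the same nitrogen, such as a methyl group, a longer carbon chain or an acetyl group, would also stay within the scatter of compound 1, or whether some would give a clear step in either direction. It also remains to be seen whether cyclopropyl on the matching nitrogen of compound 2 would give a step of similar size.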